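Adding One More Methoxy to a Flat Series

A few compounds are considered here, and "the series" means these few. Any claim that something is new, unique, unknown or untested is made for them only; others in the source may bear on it.

Values so far in a functional assay on U-373MG ATCC cells for cytotoxicity against U373 MG (Homo sapiens), read by colorimetric assay and MTT assay; on this read-out higher numbers stand for weaker inhibition and lower numbers for stronger inhibition:
- compound 1 `COc1cccc2cc(-c3ccccc3)c(O)nc12`: 10000 nM
- compound 2 `COc1ccc2cc(-c3ccccc3)c(O)nc2c1`: 10000 nM
- compound 3 `COc1ccc(-c2cc3cccc(OC)c3nc2O)cc1`: 10000 nM

All three compounds give the same number, so compound 3 (10000 nM) stands level with compound 1 and compound 2 and offers no lead in either direction. The next compound to be tested is compound 4 `COc1ccc(-c2cc3c(OC)ccc(OC)c3nc2O)cc1`. It differs from compound 3 by a single change: methoxy in place of hydrogen on an aromatic carbon. The new methoxy sits on an aromatic carbon, para to a methoxy group.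

Going by the values given here, one measured step bears on this, the same kind of swap made at another place on the molecule: no change at the digits printed from compound 1 to compound 3 (within the scatter). That is a single example at a different position, so it is only a weak guide, and the new position has not been tested. Even so, nothing measured in this assay so far points to a shift, so no step beyond the scatter is expected, in either direction. The estimated step is as follows: no change at the digits printed from compound 3 to compound 4 (within the scatter). Compound 4 is therefore expected near 10000 nM (estimated range 4000 nM to 15000 nM).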

Compound 4, half-maximal inhibitory concentration: 10000 nM
Compound 4: middle estimate and measured number agree at the digits printed; measured number inside the range.
By their numbers in this assay, from the lowest: compounds 1, 2, 3 and 4 (each within the scatter of the next).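

In this assay the new methoxy, on an aromatic carbon of the fused system and para to a methoxy group, gives no change at the digits printed from compound 3 to compound 4 (within the scatter) and so shows that filling this position does not move the printed number. Together with no change at the digits printed from compound 1 to compound 3 (within the scatter) at another place on the molecule, this makes two cases of the same swap, methoxy in place of hydrogen on an aromatic carbon, and neither step lies beyond the scatter. No measurement at hand offers an explanation for this flat result.

Still open, as far as these compounds go, is whether a group of another kind at this position, such as an amine, a carboxylic acid or a longer chain in place of the methoxy, would shift the number. With compounds 1, 2, 3 and 4 all level in this assay and no step beyond the scatter, the compounds shown also leave open which parts of the shared core, if any, have a bearing on the read-out.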